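Benzisoselenazolone-thiadiazole series: aryl substituent step toward compound 3

The source may report more compounds than this note shows. Statements on the series, on what has been measured and on what is new or still open speak of the compounds shown alone.

Measured so far in a functional assay on A549 cells (Homo sapiens) for antiproliferative activity, read by CCK-8 assay, with a stated time of 48 h; a higher number here means a weaker inhibitor, a lower number a stronger inhibitor:
compound 1, `O=c1c2ccccc2[se]n1-c1nnc(-c2ccc(Cl)cc2)s1`, 10400 nM
compound 2, `Cc1cccc(-c2nnc(-n3[se]c4ccccc4c3=O)s2)c1`, 14800 nM

Compound 2 has the highest of the two numbers in this assay; its nearest neighbour is compound 1, with the step of a 1.4-fold higher number from compound 1 to compound 2 (0.15 log units; within the scatter). That step, 3-methylphenyl in place of 4-chlorophenyl on an aromatic carbon, is the only one measured so far, and it lies within the scatter.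

Compound 3, `O=c1c2ccccc2[se]n1-c1nnc(-c2ccccc2Br)s1`, differs from compound 2 by 2-bromophenyl in place of 3-methylphenyl on an aromatic carbon. Among the measured compounds shown here, no measured step covers a halogen on this position of the phenyl ring, so the only guide is the one recorded aryl change, which moved the number by less than the scatter. The same is therefore expected here: no step beyond the scatter in this assay, in either direction. For compound 3 the expected value is 12000 nM, with a range from 5500 nM to 26000 nM, which corresponds to an estimated step of a 1.2-fold lower number from compound 2 to compound 3 (0.09 log units; within the scatter).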

Compound 3, half-maximal inhibitory concentration: 12700 nM
Compound 3: middle estimate off by 1.1-fold (0.02 log units), on the low side; measured number inside the range.
By their numbers in this assay, from the lowest: compounds 1, 3 and 2 (each within the scatter of the next).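

In this assay the substituent on the aromatic carbon of the five-membered ring now covers three aryl groups, and 2-bromophenyl joins the other two without a step beyond the scatter. Replacing 3-methylphenyl gives one such step (a 1.2-fold lower number from compound 2 to compound 3 (0.07 log units; within the scatter)) and replacing 4-chlorophenyl gives the other (a 1.2-fold higher number from compound 1 to compound 3 (0.09 log units; within the scatter)). Bromine on the phenyl ring is new to the series, yet compounds 1, 2 and 3 cannot be told apart here, and nothing at hand gives a reason for this.

Still open, as far as these compounds go, is whether the same halogen placed differently, as in 4-bromophenyl, would read the same as 2-bromophenyl. From the compounds shown here alone, it is also open whether an amine or a carboxylic acid on the phenyl ring, or a longer chain in place of that ring, would move the number beyond the scatter.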